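A few compounds are considered here, and "the series" means these few. Any claim that something is new, unique, unknown or untested is made for them only; others in the source may bear on it.

Measured compounds in this series:
compound 1 `O=C(Nc1c(F)cccc1F)O/N=C1\N[C@H](CO)[C@@H](O)[C@H](O)[C@H]1O` — > 100000 nM
compound 2 `O=C(Nc1c(Cl)cccc1C(F)(F)F)O/N=C1\N[C@H](CO)[C@@H](O)[C@H](O)[C@H]1O` — > 100000 nM

Among the measured compounds shown here, both values so far come from an assay on isolated protein for inhibition of alpha-galactosidase (Coffea arabica) (on this read-out lower numbers stand for stronger inhibition and higher numbers for weaker inhibition), and both are limits of that assay rather than numbers. In this assay compound 1 gives > 100000 nM, a limit only. Compound 2 likewise gives > 100000 nM, again a limit. For the measured compounds named here, compound 1 therefore stands at the limit alongside the only other measured value; what the numbers show is summed up by the limit of > 100000 nM in this assay, at which 2 of the 2 values shown sit. Going by the values given here, no step between measured compounds can be stated, since neither value is a number.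

Compound 3 `CC(C)(C)NC(=O)O/N=C1\N[C@H](CO)[C@@H](O)[C@H](O)[C@H]1O` differs from compound 1 by tert-butyl in place of 2,6-difluorophenyl on an amide-type nitrogen. With both measured carbamates of this core sitting at the limit, the series offers no measured step by which to judge this change, and no reason to expect a shift beyond the scatter. Compound 3 is expected to remain at or around the limit, with an estimate of 150000 nM and a range from 40000 nM to 500000 nM. The step that the limit leaves unreadable from compound 1 to compound 3 is thus expected to be none beyond the scatter, with a high chance that only a limit is reported.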

Compound 3, half-maximal inhibitory concentration: > 100000 nM
Compound 3 ended at the assay's limit; the forecaster's own chance of this, stated with the estimate: 80%; the middle value is on the limit's open side.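

Tert-butyl in place of 2,6-difluorophenyl on an amide-type nitrogen gives no readable step from compound 1 to compound 3 in this assay, because both values are limits and not numbers: the limit of > 100000 nM in this assay, at which 3 of the 3 values shown sit.

The compounds shown leave open whether any group at that nitrogen brings the shared core to a measurable value in this assay.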